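The source may report more compounds than this note shows. Statements on the series, on what has been measured and on what is new or still open speak of the compounds shown alone.

Measured compounds:
compound 1 `Cc1nn(-c2ccccn2)c2cc(-c3ccc(CCC(=O)O)cc3)ccc12` — 95%
compound 2 `O=C(O)CCc1ccc(-c2ccc3cnn(-c4ccccn4)c3c2)cc1` — 106%
compound 3 `N#Cc1nn(-c2ccccn2)c2cc(-c3ccc(CCC(=O)O)cc3)ccc12` — 124%

In a functional assay on cells for agonist activity at Free fatty acid receptor 1 (Mus musculus), read by FLIPR and calcium flux, with a stated time of 5 min (on this read-out higher numbers stand for larger maximal responses and lower numbers for smaller maximal responses), compound 2 stands second highest of the three numbers. The nearest neighbour is reached by a number 11 percentage points higher from compound 1 to compound 2 (beyond the scatter), the furthest by a number 18 percentage points higher from compound 2 to compound 3 (beyond the scatter), both beyond the scatter. Compound 4 `Cc1cc(-c2ccc(CCC(=O)O)cc2)cc2c1cnn2-c1ccccn1` differs from compound 2 by methyl in place of hydrogen on an aromatic carbon. The measured steps all concern the group varied among compounds 1, 2 and 3, on a carbon other than the one changed here; the largest is a number 29 percentage points higher from compound 1 to compound 3 (beyond the scatter), the smallest a number 11 percentage points higher from compound 1 to compound 2 (beyond the scatter), all modest. Going by the values given here, no measured step touches the carbon altered in compound 4, so no basis exists for expecting a change beyond the scatter in this assay in either direction. The expected step is a number 2 percentage points lower from compound 2 to compound 4 (within the scatter), essentially none. Compound 4 is estimated at 104%, with a range from 85% to 123%.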

Compound 4, largest response reached (reported as efficacy), in percent of the reference or control that the assay uses: 82%
Beside the measured number, compound 4's estimate is 22 percentage points above it; the measured number lies below the stated range.
By their numbers in this assay, from the lowest: compound 4; then compound 1; then compound 2; then compound 3.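

In this assay, methyl in place of hydrogen on this aromatic carbon, ortho to a fused ring, gives a number 24 percentage points lower from compound 2 to compound 4 (beyond the scatter) and shows that this position is not silent for the maximal response. Hydrogen also exceeds methyl at the carbon varied earlier, where the step is a number 11 percentage points higher from compound 1 to compound 2 (beyond the scatter), so the direction matches at both carbons in these two pairs. Nothing available explains the drop at this position.

Still open, on these data alone, is whether a nitrile on this carbon would raise the response, as it does at the other carbon. Methoxy or chlorine here also remains untested in the compounds shown.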